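From pyridin-3-yl to pyridin-4-yl on a carbonyl carbon

The source may report more compounds than this note shows. Statements on the series, on what has been measured and on what is new or still open speak of the compounds shown alone.

In a functional assay on HeLa cells (Homo sapiens) for inhibition, read by MTT assay, with a stated time of 48 h (a lower number here means a stronger inhibitor of growth, a higher number a weaker inhibitor of growth), compound 1 `Cn1cc(C2CC(c3ccc(Cl)cc3)=NN2C(=O)c2cccnc2)c2cc(Br)ccc21` reads 5200 nM and compound 2 `COc1ccc(C2=NN(C(=O)c3cccnc3)C(c3cn(C)c4ccc(Br)cc34)C2)cc1OC` reads 2090 nM as the lower of the two numbers. For the measured compounds named here, the one measured step is modest, a 2.5-fold lower number from compound 1 to compound 2 (0.40 log units; beyond the scatter) with 3,4-dimethoxyphenyl in place of 4-chlorophenyl on a carbon with a double bond to nitrogen. Compound 3 `COc1ccc(C2=NN(C(=O)c3ccncc3)C(c3cn(C)c4ccc(Br)cc34)C2)cc1OC` has the same atoms as compound 2 but carries pyridin-4-yl in place of pyridin-3-yl on a carbonyl carbon and differs nowhere else. Going by the values given here, the measured step lies at another place in the molecule, so it says little about this change, and no measured pair tests it. No direction can be argued from these data, so in this assay the expected outcome is no shift beyond the scatter, an estimated 1.0-fold higher number from compound 2 to compound 3 (0.00 log units; within the scatter) in size. The estimate for compound 3 is 2100 nM with 800 nM to 5500 nM as the expected range.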

Compound 3, concentration for 50% growth inhibition: > 10000 nM
Compound 3 ended at the assay's limit; the forecaster's own chance of this, stated with the estimate: 2%; middle value at least 4.7-fold (0.67 log units) away from the limit.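

In this assay, pyridin-4-yl in place of pyridin-3-yl on the carbonyl carbon gives an at least 4.7-fold higher number from compound 2 to compound 3 (0.67 log units; beyond the scatter), which means weaker growth inhibition even though the atoms are the same and only the way they are joined differs. This shows that the position is sensitive to how the pyridine ring is attached, which compound 1 and compound 2 could not reveal, as both carry pyridin-3-yl. The reading for compound 3 is a limit of the assay and not a number, so the step has a known minimum but no known full size: the limit of > 10000 nM in this assay, at which 1 of the 3 values shown sits.

Going by these compounds, it remains open whether pyridin-2-yl or a plain phenyl on the same carbonyl carbon would keep the growth inhibition of compound 2. Also open, on these data alone, is whether the same swap would have a similar effect with the 4-chlorophenyl of compound 1 in place of 3,4-dimethoxyphenyl.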